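The source may hold more compounds than are shown below. What is called first, only, known or untested is meant among the compounds shown, and "the series" means these compounds.

Working notes on the series. All three measured compounds share one core and differ only in the aryl group attached to it: compound 1 `O=C(CCc1ccc(-c2ccccc2F)cc1)N1CCCC1` carries a 2-fluorophenyl, compound 2 `O=C(CCc1ccc(-c2ccc(F)cc2)cc1)N1CCCC1` a 4-fluorophenyl, and compound 3 `O=C(CCc1ccc(-c2ccccn2)cc1)N1CCCC1` a pyridin-2-yl. In an assay on HEK293 cells for inhibition of N-acylethanolamine-hydrolyzing acid amidase (Rattus norvegicus), read by LC-MS, with a stated time of 30 min (a lower number here means a stronger inhibitor, a higher number a weaker inhibitor), compound 1 gives 2800 nM and compound 2 gives 3400 nM; the step of a 1.2-fold higher number from compound 1 to compound 2 (0.08 log units; within the scatter). For compound 3 this assay reports only a limit, > 100000 nM, and no number. Compound 3 therefore stands at the weak end of the set, at the limit of > 100000 nM in this assay, at which 1 of the 3 values shown sits, and the steps of an at least 35-fold higher number from compound 1 to compound 3 (1.55 log units; beyond the scatter) and an at least 29-fold higher number from compound 2 to compound 3 (1.46 log units; beyond the scatter) are both large. The next compound, compound 4 `O=C(CCc1ccc(-c2ccsc2)cc1)N1CCCC1`, differs from compound 3 in one place: thiophen-3-yl in place of pyridin-2-yl on an aromatic carbon. The two large steps bear directly on this change, since both show that the pyridin-2-yl sits far from the fluorophenyl pair; leaving it is expected to reverse most of that loss, a large step downward in this assay, an at least 25-fold lower number from compound 3 to compound 4 (1.39 log units; beyond the scatter). Compound 4 is expected at 4000 nM, with a range from 1500 nM to 20000 nM.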

Compound 4, half-maximal inhibitory concentration: 2500 nM
Beside the measured number, compound 4's estimate is 1.6-fold (0.20 log units) above it, within the range that was stated.
By their numbers in this assay, from the lowest: compounds 4, 1 and 2 (each within the scatter of the next). At a limit, above all of these: compound 3.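

In this assay this position tolerates a five-membered aromatic ring with sulfur as its hetero atom, and the loss seen with the pyridin-2-yl does not extend to every heteroaryl group: an at least 40-fold lower number from compound 3 to compound 4 (1.60 log units; beyond the scatter). The thiophen-3-yl stays within the scatter of both fluorophenyl groups (a 1.4-fold lower number from compound 2 to compound 4 (0.13 log units; within the scatter)) and (a 1.1-fold lower number from compound 1 to compound 4 (0.05 log units; within the scatter)), so across these compounds neither ring size nor the presence of a hetero atom alone goes with the loss. Compound 3 remains alone at a limit: the limit of > 100000 nM in this assay, at which 1 of the 4 values shown sits.

Still open, from the compounds shown here alone, is whether a pyridin-3-yl or pyridin-4-yl would share the loss, which would show whether it follows the ring nitrogen or its placement. Also open, going by these compounds, is how a thiophen-2-yl, or an aryl ring bearing an amine or a carboxylic acid, would read in this assay.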